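This account rests on a few compounds, and the source may have more. Where it says the series, first, only, none or still open, it means among the compounds named here.

Among the measured compounds shown here, compound 2 `CN(C)c1ccc(C2CC(c3ccc(-n4ccnc4)cc3)=NN2C(=O)c2ccc(F)cc2)cc1` gives 7.1% in a functional assay on HCC1806 cells (Homo sapiens) for inhibition, read by sulforhodamine B assay, tested at 10 uM; a lower number here means less inhibition, a higher number more inhibition at the concentration tested (going by the name of the read-out); of the two numbers measured so far it sits at the bottom, but compound 1 `CN(C)c1ccc(C2CC(c3ccc(-n4cncn4)cc3)=NN2C(=O)c2ccc(F)cc2)cc1` gives 15.6%, and the step of a number 8.5 percentage points lower from compound 1 to compound 2 (within the scatter) lies within the scatter, so the two are not distinguished. Compound 3 `CN(C)c1ccc(C2CC(c3ccc(-n4ccnc4)cc3)=NN2S(=O)(=O)c2ccc([N+](=O)[O-])cc2)cc1` differs from compound 2 by (4-nitrophenyl)sulfonyl in place of (4-fluorophenyl)carbonyl on an amine nitrogen in a ring. For the measured compounds named here, no measured step touches the group on the ring nitrogen; the single step from compound 1 to compound 2 concerns the five-membered heteroaryl ring and was within the scatter, so it gives no guide to this change. The step of a number 4.9 percentage points higher from compound 2 to compound 3 (within the scatter) is therefore expected to stay within the scatter. Compound 3 is estimated at 12% in this assay, with a range from 0% to 35%.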

Compound 3, a percentage reported as inhibition, at one concentration (the size of the read-out at that concentration, not a potency): 46.6%
Estimate against measurement, compound 3: 34.6 percentage points below, outside the stated range (above it).
By their numbers in this assay, from the lowest: compounds 2 and 1 (each within the scatter of the next); then compound 3.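

In this assay, among the compounds shown here, the group on the amine nitrogen in a ring proves able to move the number: (4-nitrophenyl)sulfonyl in place of (4-fluorophenyl)carbonyl gives a number 39.5 percentage points higher from compound 2 to compound 3 (beyond the scatter) and is the only step so far beyond the scatter. The earlier step at the five-membered heteroaryl ring did not separate its two compounds, so of the two places varied, only this one has shown an effect. Nothing available explains this result.

The change replaces the carbonyl link and the ring substituent together, so their shares remain unresolved. Open, as far as these compounds go, is whether (4-fluorophenyl)sulfonyl or (4-nitrophenyl)carbonyl on this nitrogen would carry the step.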